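Ethoxy to 2-hydroxyethoxy: the next point in the series

A few compounds are considered here, and "the series" means these few. Any claim that something is new, unique, unknown or untested is made for them only; others in the source may bear on it.

Three compounds with the same core and the same ethoxy group have been measured, and they differ only in the heteroaryl group on a double-bonded ring carbon. In a physicochemical assay for lipophilicity, at pH 7.4 (on this read-out higher numbers stand for higher lipophilicity and lower numbers for lower lipophilicity), compound 1 `CCOc1ccc2c(c1)C(c1cnn(C)c1)=CN(C)C(=O)[C@@H]2C` gives 4.1, compound 3 `CCOc1ccc2c(c1)C(c1cn(C)cn1)=CN(C)C(=O)[C@@H]2C` gives 3.6 and compound 2 `CCOc1ccc2c(c1)C(c1c[nH]c(C)n1)=CN(C)C(=O)[C@@H]2C` gives 3.1. Compound 2 is the lowest of the three, and compound 3 is its nearest neighbour.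

Compound 4 `Cc1nc(C2=CN(C)C(=O)[C@H](C)c3ccc(OCCO)cc32)c[nH]1` keeps the 2-methyl-1H-imidazol-4-yl group of compound 2. The difference is hydroxy in place of hydrogen on a saturated chain carbon, two bonds along the chain from an oxygen on an aromatic ring, which can also be read as ethoxy to 2-hydroxyethoxy.

Among the measured compounds shown here, no measured step touches this place, so there is no direct precedent for the change. The heteroaryl swaps give a number 1.00 log units lower from compound 1 to compound 2 (beyond the scatter), a number 0.50 log units lower from compound 1 to compound 3 (beyond the scatter) and a number 0.50 log units higher from compound 2 to compound 3 (beyond the scatter). These show only how far this assay has moved within the series, so they offer a scale and no direction.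

Judging from the structural change itself, a step to a lower number is expected, close in size to the largest of those swaps. The estimated step is a number 0.90 log units lower from compound 2 to compound 4 (beyond the scatter). For compound 4 the expected value is 2.2, with an estimated range from 1.7 to 2.7.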

Compound 4, distribution coefficient: 1.5
The estimate for compound 4 lay 0.70 log units above the measured number; measured number outside the range, below it.
By their numbers in this assay, from the lowest: compound 4; then compound 2; then compound 3; then compound 1.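

In this assay, the ethoxy chain turns out to be a place where one small change moves the number further than any of the heteroaryl swaps: hydroxy in place of hydrogen on a saturated chain carbon, two bonds along the chain from an oxygen on an aromatic ring, gives a number 1.60 log units lower from compound 2 to compound 4 (beyond the scatter), a large step where the swaps were all modest. The earlier compounds shown here varied only the heteroaryl group and held no reading of this place; compound 4, at 1.5, now sets the low end of the series with the 2-methyl-1H-imidazol-4-yl group unchanged. No measured information available here accounts for the size of this step.

As far as these compounds go, this reading rests on a single pair, so it remains open whether the same change gives a comparable step with the 1-methyl-1H-pyrazol-4-yl group of compound 1 or the 1-methyl-1H-imidazol-4-yl group of compound 3. Also open, from the compounds shown here alone, is how the number responds to an amine or a carboxylic acid in place of the hydroxy, or to a longer chain carrying the hydroxy.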